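Trifluoromethyl in Place of Methyl: One Change, One Expectation

The source may report more compounds than this note shows. Statements on the series, on what has been measured and on what is new or still open speak of the compounds shown alone.

Compound 1 `COc1cccc(C(=O)Oc2cc3c(cc2C)[C@@H](C(C)C)CC=C3C)c1`: "not active" (no number reported)
Compound 2 `CC1=CC[C@H](C(C)C)c2cc(C)c(OC(=O)c3ccc(C)cc3)cc21`: 100%

In a functional assay on K562 cells (Homo sapiens) for antiproliferative activity, read by sulforhodamine B assay, with a stated time of 48 h, tested at 50 uM (on this read-out higher numbers stand for more inhibition at the one concentration tested (going by the name of the read-out) and lower numbers for less inhibition), compound 1 gives "not active" (no number reported). Compound 2 gives 100% in this assay, which is the only number shown; compound 1 is the sole other entry and carries no number. Compound 3 `CC1=CC[C@H](C(C)C)c2cc(C)c(OC(=O)c3ccc(C(F)(F)F)cc3)cc21` differs from compound 2 by trifluoromethyl in place of methyl on an aromatic carbon. For the measured compounds named here, no step between two measured compounds is available to guide the size of this change. The expected step is a number 12 percentage points lower from compound 2 to compound 3 (beyond the scatter), a small downward move within or near the scatter, because compound 2 stands at 100%. Compound 3 is estimated at 88%, in the range 55% to 100%.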

Compound 3, a percentage reported as inhibition, at one concentration (the size of the read-out at that concentration, not a potency): 9%
Beside the measured number, compound 3's estimate is 79 percentage points above it; the whole stated range lies above it.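

In this assay trifluoromethyl in place of methyl gives a number 91 percentage points lower from compound 2 to compound 3 (beyond the scatter) and so shows that the group on this aromatic carbon, para to a large group, strongly affects inhibition at the one concentration tested. For the compounds shown here, the earlier compounds offered no step between two measured numbers, so this is the first measure of how much a change here can matter. Nothing at hand explains the size of this step. As far as these compounds go, it remains open whether an amine, a chlorine atom or a longer chain at this position would behave like methyl or like trifluoromethyl.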